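The source may report more compounds than this note shows. Statements on the series, on what has been measured and on what is new or still open speak of the compounds shown alone.

All three measured compounds were run in a functional assay on HepG2 cells (Homo sapiens) for cytotoxicity, read by MTT assay, with a stated time of 48 h (on this read-out higher numbers stand for weaker inhibition and lower numbers for stronger inhibition), and each sits at the upper limit of the assay:

Compound 1, `CCc1nnc(SC)n1N1C(=O)c2ccccc2C1=O`, gave > 200000 nM, a limit rather than a number.
Compound 2, `CCCc1nnc(SCC(=O)c2ccc(Cl)cc2)n1N1C(=O)c2ccccc2C1=O`, gave > 200000 nM, again a limit.
Compound 3, `C=CCSc1nnc(-c2cc(OC)c(OC)c(OC)c2)n1N1C(=O)c2ccccc2C1=O`, gave > 200000 nM, also a limit.

Compound 3 therefore stands where every other compound here stands: at the limit, with no number to place it above or below its neighbours. Among the measured compounds shown here, nothing beyond the limit of > 200000 nM in this assay, at which 3 of the 3 values shown sit, is known, and no step between two measured compounds can be counted, since a difference between two limits has no size.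

Compound 4 is `COc1cc(-c2nnc(SCC(=O)c3ccc(Cl)cc3)n2N2C(=O)c3ccccc3C2=O)cc(OC)c1OC`. Against compound 3 the change is (4-chlorophenyl)carbonyl in place of vinyl on a saturated chain carbon bound to a sulfur. In words: (4-chlorophenyl)carbonyl in place of vinyl on a saturated chain carbon bound to a sulfur.

For the measured compounds named here, with no measured step to lean on, the expectation is a step that the limit leaves unreadable from compound 3 to compound 4, that is, none beyond the scatter, and most likely another limit. Compound 4 is expected to give about 300000 nM in this assay, within 100000 nM to 1000000 nM.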

Compound 4, half-maximal inhibitory concentration: 22000 nM
The estimate for compound 4 lay 14-fold (1.13 log units) above the measured number, outside the stated range (below it).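

Among the compounds shown here, compound 4 is the first compound here to give a real number in this assay, while steps among the three earlier compounds cannot be read. Placing (4-chlorophenyl)carbonyl in place of vinyl on a saturated chain carbon bound to a sulfur gives an at least 9.0-fold lower number from compound 3 to compound 4 (0.95 log units; beyond the scatter), and placing 3,4,5-trimethoxyphenyl in place of propyl on an aromatic carbon gives an at least 9.0-fold lower number from compound 2 to compound 4 (0.95 log units; beyond the scatter). Compound 2 carries only the first of these groups and compound 3 only the second, so among these compounds a measurable number appears only with both together, and the true size of each step stays unknown because both starting compounds sit at a limit: the limit of > 200000 nM in this assay, at which 3 of the 4 values shown sit.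

The compounds shown leave open whether an amine or a carboxylic acid in place of the chlorine would give a similar number. They also leave open what a longer chain in place of the 3,4,5-trimethoxyphenyl would do.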